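This account rests on a few compounds, and the source may have more. Where it says the series, first, only, none or still open, it means among the compounds named here.

Compound 2 (`O=C(COc1ccc2cc(/C=C3/SC(=O)NC3=O)ccc2c1)Nc1cccc(C(F)(F)F)c1`) is measured in an assay on isolated protein for inhibition of histone deacetylase 8 (Homo sapiens), with a stated time of 1 h (a higher number here means a weaker inhibitor, a lower number a stronger inhibitor), where it gives > 50000 nM; this figure is a limit of the assay rather than a number. Compound 1 (`O=C(COc1ccc2cc(/C=C3/SC(=O)NC3=O)ccc2c1)Nc1ccccn1`) also gives a limit in this assay, > 50000 nM. Going by the values given here, the one measured step, a step that the two limits leave unreadable from compound 1 to compound 2, therefore cannot be read in size or direction, and the only evidence available is the limit of > 50000 nM in this assay, at which 2 of the 2 values shown sit, which places both compounds at the same edge of what the assay can report.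

Compound 3 (`COc1ccc(NC(=O)COc2ccc3cc(/C=C4/SC(=O)NC4=O)ccc3c2)cc1`) is not yet measured. It differs from compound 2 in a single place: 4-methoxyphenyl in place of 3-(trifluoromethyl)phenyl on an amide-type nitrogen. Among the compounds with values here, no measured step bears on this change, so nothing in the data suggests a gain or loss beyond the scatter, and the most that can be said is that compound 2 itself sits at a limit.

Compound 3 is therefore expected to remain at or near that limit in this assay, with an estimated value of 60000 nM within a range of 20000 nM to 200000 nM. The step this estimate implies, a step that the limit leaves unreadable from compound 2 to compound 3, is expected to be no more than scatter.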

Compound 3, half-maximal inhibitory concentration: > 50000 nM
Compound 3: no number, only a limit (the forecaster's own chance of this, stated with the estimate: 85%); the middle value lies beyond the limit too.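

In this assay compound 3 gives > 50000 nM, which is a limit and not a number. Going by these compounds alone, no step among compound 1, compound 2 and compound 3 can therefore be read, in size or in direction: the limit of > 50000 nM in this assay, at which 3 of the 3 values shown sit. The compounds shown leave open whether any group on the amide-type nitrogen can give a real number in this assay.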